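The source may report more compounds than this note shows. Statements on the series, on what has been measured and on what is new or still open speak of the compounds shown alone.

Measured in a functional assay on HepG2 cells (Homo sapiens) for antiproliferative activity, read by MTT assay; on this read-out higher numbers stand for weaker inhibition and lower numbers for stronger inhibition:
compound 1, `CNC(=O)c1ccc(Oc2cccc(NC(=S)Nc3ccc(F)cc3)c2)nc1`, gives 42500 nM.
compound 2, `CNC(=O)c1ccc(Oc2cccc(NC(=S)Nc3ccc(OC(F)(F)F)cc3)c2)nc1`, gives only a limit of the assay, > 100000 nM.
compound 3, `CNC(=O)c1ccc(Oc2cccc(NC(=S)Nc3ccc(F)c(C(F)(F)F)c3)c2)nc1`, gives 20200 nM.

Among the two actual numbers, compound 1 stands highest, with its nearest neighbour compound 3 reached by a 2.1-fold lower number from compound 1 to compound 3 (0.32 log units; beyond the scatter). The value of compound 2 sits at the limit of > 100000 nM in this assay, at which 1 of the 3 values shown sits.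

Compound 4, `CNC(=O)c1ccc(Oc2cccc(NC(=S)Nc3ccc(Cl)cc3Cl)c2)nc1`, differs from compound 1 in one place: 2,4-dichlorophenyl in place of 4-fluorophenyl on an amide-type nitrogen. Among the measured compounds shown here, two measured steps touch the same part of the shared core. Trifluoromethoxy in place of fluoro gave an at least 2.3-fold higher number from compound 1 to compound 2 (0.37 log units; beyond the scatter), while trifluoromethyl in place of hydrogen gave a 2.1-fold lower number from compound 1 to compound 3 (0.32 log units; beyond the scatter). Neither step places chlorine on this ring, so they point in opposite directions and only loosely to the change made here: a larger halogen replaces fluoro and a second chlorine is added. On this basis the step from compound 1 to compound 4 is expected to be small, of the order of the scatter, with a slight lean toward a lower number in this assay.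

Compound 4 is therefore estimated at 30000 nM, with a range from 12000 nM to 80000 nM, which means an expected step of a 1.4-fold lower number from compound 1 to compound 4 (0.15 log units; within the scatter).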

Compound 4, half-maximal inhibitory concentration: 21600 nM
The estimate for compound 4 lay 1.4-fold (0.14 log units) above the measured number; the measured number falls inside the stated range.
By their numbers in this assay, from the lowest: compounds 3, 4 and 1 (each within the scatter of the next, the first and the last beyond it). At a limit, above all of these: compound 2.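

In this assay, putting 2,4-dichlorophenyl in place of 4-fluorophenyl on the amide-type nitrogen gives a 2.0-fold lower number from compound 1 to compound 4 (0.29 log units; within the scatter), so this pair cannot be told apart in this test. Among the compounds shown here, the earlier compounds carried only fluorine-containing groups on this ring, and compound 4 adds the first evidence that the ring can hold chlorine, even two chlorine atoms, with no change that stands clear of the scatter. No measurement shown here explains how this swap acts on the cells, and the result is best read as tolerance of the change rather than a gain.

The compounds shown leave open what each chlorine contributes on its own, which a 4-chlorophenyl group would help to separate from the effect of carrying two chlorine atoms. They also leave open how this position would respond to a quite different kind of group on the ring, such as an amine or a carboxylic acid, since every substituent seen so far on this ring contains a halogen.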